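This account rests on a few compounds, and the source may have more. Where it says the series, first, only, none or still open, it means among the compounds named here.

Measured compounds in an ADME assay on Vero cells (Chlorocebus sabaeus) for cytotoxicity, read by MTT assay, with a stated time of 72 h; a higher number here means a weaker inhibitor, a lower number a stronger inhibitor:
compound 1, `O=C(c1ccncc1)N1N=C(c2cc3ccccc3o2)CC1c1ccc(O)cc1`: > 200000 nM
compound 2, `O=C(c1ccncc1)N1N=C(c2cc3ccccc3o2)CC1c1ccc(Cl)cc1`: > 220000 nM
compound 3, `CCn1cc(C(=O)N2N=C(c3cc4ccccc4o3)CC2c2ccc(N(C)C)cc2)c(=O)c2ccc(C)nc21`: > 206000 nM

Compound 1 gives in this assay > 200000 nM, which is a limit of the assay and not a number. Compound 2 likewise gives > 220000 nM, again a limit. Compound 3 gives > 206000 nM, also a limit. All three values shown are therefore limits, as recorded in the limit of > 200000 nM in this assay, at which 1 of the 3 values shown sits, the limit of > 206000 nM in this assay, at which 1 of the 3 values shown sits, and (the limit of > 220000 nM in this assay, at which 1 of the 3 values shown sits), and compound 3 stands at one of them with no number of its own. Among the measured compounds shown here, the only step between compounds that differ in a single place is a step that the two limits leave unreadable from compound 1 to compound 2, and the two limits leave its size unreadable.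

Compound 4, `CCn1cc(C(=O)N2N=C(c3cc4ccccc4o3)CC2c2ccc(O)cc2)c(=O)c2ccc(C)nc21`, differs from compound 3 by hydroxy in place of dimethylamino on an aromatic carbon. For the measured compounds named here, the step from compound 1 to compound 2 is the only measured step that concerns a change on the same phenyl position, and it yields no readable size, so nothing in the data points to a step beyond the scatter in either direction. The step of an at least 1.0-fold lower number from compound 3 to compound 4 (0.01 log units; that floor lies within the scatter) is therefore expected to be none beyond the scatter. For compound 4 in this assay the estimate is 200000 nM, expected to lie between 100000 nM and 1000000 nM, most probably reported again only as a limit.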

Compound 4, half-maximal inhibitory concentration: > 148000 nM
Compound 4: only a limit was reported (the forecaster's own chance of this, stated with the estimate: 85%); the middle value lies beyond the limit too.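

In this assay compound 4 gives > 148000 nM, which is a limit of the assay and not a number. Among the compounds shown here, compound 3 also stands at a limit, so no step between compound 3 and compound 4 can be read. The compounds shown leave open what number any of the four would reach in this assay.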